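A Decyl Chain in Place of a Hydroxyphenyl Group

The source may report more compounds than this note shows. Statements on the series, on what has been measured and on what is new or still open speak of the compounds shown alone.

Of the compounds shown here, three built on one shared core have been tested in a functional assay on CFPAC-1 cells (Homo sapiens) for antiproliferative activity, read by MTT assay, with a stated time of 72 h; on this read-out lower numbers stand for stronger inhibition and higher numbers for weaker inhibition. Compound 1 `O=C1O/C(=C\Cn2cc(-c3ccc(Br)cc3)nn2)C(OCc2ccccc2)=C1OCc1ccccc1` reaches only a limit of the assay, giving > 100000 nM. Compound 3 `O=C1O/C(=C\Cn2cc(-c3cc(C(F)(F)F)cc(C(F)(F)F)c3)nn2)C(OCc2ccccc2)=C1OCc1ccccc1` likewise stops at a limit, with > 100000 nM. Compound 2 `O=C1O[C@H]([C@@H](O)Cn2cc(-c3cccc(O)c3)nn2)C(OCc2ccccc2)=C1OCc1ccccc1` is the only one of the three that yields an actual number in this assay, namely 54100 nM, while the two other values sit at the limit of > 100000 nM in this assay, at which 2 of the 3 values shown sit. Compound 2 therefore stands alone as the single measured point against which anything new can be judged.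

Compound 4 `CCCCCCCCCCc1cn(C[C@H](O)[C@H]2OC(=O)C(OCc3ccccc3)=C2OCc2ccccc2)nn1` has not yet been measured. It differs from compound 2 in one place: decyl in place of 3-hydroxyphenyl on an aromatic carbon. For the measured compounds named here, no step between two measured compounds carries a change of this kind, so the size of the step can only be expected rather than read off. Compound 4 is expected to be somewhat stronger than compound 2, a step of a 2.7-fold lower number from compound 2 to compound 4 (0.43 log units; beyond the scatter), beyond the usual scatter but not by a wide margin. In this assay compound 4 is estimated at 20000 nM, with a plausible range from 5000 nM to 90000 nM.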

Compound 4, half-maximal inhibitory concentration: 40300 nM
Compound 4: the middle estimate sits 2.0-fold (0.30 log units) below what was measured, within the range that was stated.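

In this assay, decyl in place of 3-hydroxyphenyl gives a 1.3-fold lower number from compound 2 to compound 4 (0.13 log units; within the scatter). For the compounds shown here, that is the first step read at this aromatic carbon, and it shows that a ring with one hydrogen-bond donor and one hydrogen-bond acceptor can give way to an open chain with neither, with no change in the read-out beyond the scatter. The data shown offer no measured reason why two such different groups give values this close.

Going by these compounds, it remains open whether the read-out at this position responds to any group at all, since only these two groups can be compared here. A shorter chain such as butyl, or a decyl chain ending in an amine or a carboxylic acid, would test this further.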